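Working notes on cytotoxicity for compounds 1 to 4

This account rests on a few compounds, and the source may have more. Where it says the series, first, only, none or still open, it means among the compounds named here.

Measured so far:
compound 1 `COc1ccc(Cn2nc(-c3ccccc3)c3cc(C(=N)Nc4ccc(N5CCN(C)CC5)cc4)nc(NC4CCCCC4)c32)cc1`: 3330 nM
compound 2 `Cn1nc(-c2ccccc2)c2cc(C(=N)Nc3ccccc3)ncc21`: "not determined" (no result reported)
compound 3 `CN1CCN(c2ccc(NC(=N)c3cc4c(-c5ccccc5)nn(C)c4cn3)cc2)CC1`: 10400 nM

In an ADME assay on AG1523 cells (Homo sapiens) for cytotoxicity, read by MTT assay, with a stated time of 72 h (a higher number here means a weaker inhibitor, a lower number a stronger inhibitor), compound 1 gives 3330 nM. Compound 2 gives "not determined" (no result reported) in this assay and offers nothing for comparison. Compound 3 gives 10400 nM, the higher of the two numbers available; its nearest neighbour is compound 1, and that gap lies beyond the usual scatter, so compound 3 is the weaker inhibitor of the two.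

Compound 4 `COc1ccc(Cn2nc(-c3ccccc3)c3cc(C(=N)Nc4ccc(N5CCN(C)CC5)cc4)ncc32)cc1` is not yet measured in this assay. It differs from compound 3 in a single place: 4-methoxyphenyl in place of hydrogen on a saturated chain carbon bound to an aromatic nitrogen. Among the measured compounds shown here, compound 1 also carries 4-methoxybenzyl and sits at the lower number, but compound 1 differs from compound 4 elsewhere as well, so no isolated step for this change is at hand among the measured compounds.

On that basis the step is expected to be a 2.1-fold lower number from compound 3 to compound 4 (0.32 log units; beyond the scatter), toward a lower number and of moderate size, somewhat beyond the scatter. Compound 4 is expected to give 5000 nM, with a range from 2000 nM to 14000 nM.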

Compound 4, half-maximal inhibitory concentration: 10200 nM
Compound 4: the middle estimate sits 2.0-fold (0.31 log units) below what was measured, within the range that was stated.
By their numbers in this assay, from the lowest: compound 1; then compounds 4 and 3 (each within the scatter of the next).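

In this assay the exchange of methyl for 4-methoxybenzyl, on a saturated chain carbon bound to an aromatic nitrogen, gives a 1.0-fold lower number from compound 3 to compound 4 (0.01 log units; within the scatter) and so leaves the number in place within the scatter. The 4-methoxybenzyl group on its own therefore does not account for the lower number of compound 1, and the step beyond the scatter in this set lies at the other place, where hydrogen stands in place of cyclohexylamino on an aromatic carbon: a 3.1-fold higher number from compound 1 to compound 4 (0.49 log units; beyond the scatter) is a modest change at that aromatic carbon. No measurement at hand gives a reason for either step.

On these data alone, it remains open whether other groups at the chain position, such as unsubstituted benzyl or a longer chain ending in an amine, would also leave the number in place, and whether the flat step from methyl to 4-methoxybenzyl would hold with cyclohexylamino present. As far as these compounds go, it also remains open whether the modest step at the aromatic carbon is specific to cyclohexylamino or would also appear with a smaller group such as methylamino or with a morpholine.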